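The compounds below may be only part of what the source reports. "The series", "measured", "known", "first", "only" and "open" are said of these compounds alone.

Series notes. Compound 1 `CCCN(CCC)S(=O)(=O)c1ccc(S(=O)(=O)N2CCC[C@@H](C(=O)OCC)C2)cc1` is the reference point. In a functional assay on MIA PaCa-2 cells (Homo sapiens) for inhibition, read by MTT assay, with a stated time of 3 days (on this read-out higher numbers stand for weaker inhibition and lower numbers for stronger inhibition), compound 1 gives 600 nM, the second highest of the three numbers at hand. Compound 2 `CCOC(=O)[C@@H]1CCCN(S(=O)(=O)c2ccc(S(=O)(=O)N(CC)CC)c(F)c2)C1` gives 200 nM in this assay, a lower number, beyond the scatter. Compound 3 `CCOC(=O)[C@@H]1C[C@@H](O)CN(S(=O)(=O)c2ccc(S(=O)(=O)N(CC)CC)cc2)C1` gives 2100 nM in this assay, a higher number, also beyond the scatter. Within the data shown here, neither compound differs from compound 1 in a single place, so no single-change step is available from the measured set. Compound 4 `CCOC(=O)[C@@H]1CCCN(S(=O)(=O)c2ccc(S(=O)(=O)N3CCCCC3)cc2)C1` differs from compound 1 by piperidin-1-yl in place of dipropylamino on a sulfonyl sulfur, a ring in place of the open chains. Among the measured compounds shown here, with no measured step of this kind to lean on, the step expected in this assay is a 1.2-fold lower number from compound 1 to compound 4 (0.08 log units; within the scatter), that is, none beyond the scatter. Compound 4 is accordingly estimated at 500 nM in this assay, within 200 nM to 1500 nM.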

Compound 4, half-maximal inhibitory concentration: 1000 nM
For compound 4 the middle estimate is 2.0-fold (0.30 log units) below the measured one; low and high end bracket the measured number.
By their numbers in this assay, from the lowest: compound 2; then compounds 1 and 4 (each within the scatter of the next); then compound 3.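

Among these compounds, this is the first single-place step. On the sulfonyl sulfur, piperidin-1-yl in place of dipropylamino gives a 1.7-fold higher number from compound 1 to compound 4 (0.22 log units; within the scatter) in this assay, so this one ring and the open chains of compound 1 are not told apart here. The reading covers this one pair only.

On these data alone, whether morpholin-4-yl, with a second hetero atom in the ring, or the longer chains of dibutylamino at this place would move the number beyond the scatter remains open. No measurement at hand offers an explanation for this step.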